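The source may report more compounds than this note shows. Statements on the series, on what has been measured and on what is new or still open speak of the compounds shown alone.

Compound 1 `Cn1cc(-c2nn(Cc3ccc(C(=O)N4CCCCC4)cc3)c(=O)c3ccccc23)cn1`: 67400 nM
Compound 2 `CN1CCC(NC(=O)c2ccc(Cn3nc(-c4cnn(C)c4)c4ccccc4c3=O)cc2)CC1`: 54300 nM
Compound 3 `Cc1noc(C)c1-c1nn(Cc2ccc(C(=O)NC3CC3)cc2)c(=O)c2ccccc12`, a limit of the assay only: > 100000 nM

In a functional assay on A549 cells (Homo sapiens) for antiproliferative activity, read by MTT assay, with a stated time of 72 h (a higher number here means a weaker inhibitor, a lower number a stronger inhibitor), compound 2 gives 54300 nM. Among the measured compounds shown here, the one step measured at the amide end, a 1.2-fold lower number from compound 1 to compound 2 (0.09 log units; within the scatter), lies within the scatter, so compound 1 and compound 2 are not told apart here. Compound 3 carries a different group on the shared core and reports only a limit, (the limit of > 100000 nM in this assay, at which 1 of the 3 values shown sits).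

Compound 4 `Cn1cc(-c2nn(Cc3ccc(C(=O)NC4CCCC4)cc3)c(=O)c3ccccc23)cn1` arises from compound 2 by cyclopentyl in place of 1-methylpiperidin-4-yl on an amide-type nitrogen. For the measured compounds named here, the only step that bears on it is the amide-end change from compound 1 to compound 2, and that step stayed within the scatter. The expected step of a 1.1-fold higher number from compound 2 to compound 4 (0.04 log units; within the scatter) is therefore none beyond the scatter. Compound 4 is estimated at 60000 nM, between 28000 nM and 130000 nM.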

Compound 4, half-maximal inhibitory concentration: 32300 nM
For compound 4 the middle estimate is 1.9-fold (0.27 log units) above the measured one; measured number inside the range.
By their numbers in this assay, from the lowest: compounds 4, 2 and 1 (each within the scatter of the next, the first and the last beyond it). At a limit, above all of these: compound 3.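

At the amide end, cyclopentyl in place of 1-methylpiperidin-4-yl gives a 1.7-fold lower number from compound 2 to compound 4 (0.23 log units; within the scatter), so the ring nitrogen of compound 2 makes no difference that can be read here. Cyclopentylamino in place of piperidin-1-yl gives a 2.1-fold lower number from compound 1 to compound 4 (0.32 log units; beyond the scatter), the first step at this position to pass the scatter, though only a modest one. Nothing measured here explains that step. Still open, as far as these compounds go, is whether a carboxylic acid or a longer chain on this amide nitrogen would shift the number further.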